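The source may report more compounds than this note shows. Statements on the series, on what has been measured and on what is new or still open speak of the compounds shown alone.

Compound 1 `Cc1cc(C)nc(SCc2cc(=O)c3cc(Cl)ccc3o2)n1`: in a functional assay on MDA-MB-435S cells (Homo sapiens) for cytotoxicity, read by MTT assay, with a stated time of 72 h (on this read-out higher numbers stand for weaker inhibition and lower numbers for stronger inhibition), compound 1 reaches only the limit > 25000 nM. Compound 2 `Cc1nnc(SCc2coc3ccccc3c2=O)s1`: compound 2 gives 630 nM. Compound 3 `Cc1nnc(Sc2c(C)oc3ccccc3c2=O)o1`: compound 3 reaches only the limit > 50000 nM.

Among the three values shown, compound 1 stands at a limit rather than a number, recorded as the limit of > 25000 nM in this assay, at which 1 of the 3 values shown sits. Compound 3 also sits at a limit. Only compound 2 carries a numerical value. Among the compounds with values here, no two measured compounds differ in a single place, so no measured step is available for guidance.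

Compound 4 `Cc1ccc2oc(CSc3nc(C)cc(C)n3)cc(=O)c2c1` differs from compound 1 by methyl in place of chloro on an aromatic carbon. Within the data shown here, with no measured step to lean on, the change is expected to be small, within the scatter, leaving compound 4 at or near the limit. The step is estimated as a step that the limit leaves unreadable from compound 1 to compound 4. Compound 4 is thus estimated at 30000 nM, between 8000 nM and 100000 nM.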

Compound 4, half-maximal inhibitory concentration: > 25000 nM
Compound 4: only a limit was reported; the forecaster's own chance of this, stated with the estimate: 70%; the middle value is on the limit's open side.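

Compound 4 reaches only a limit, > 25000 nM. Within the data shown here, compound 1 also stands at a limit, and no step between compound 1 and compound 4 can be read. The compounds shown leave open how methyl and chloro on this aromatic carbon compare in this assay.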